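From compound 2 to compound 4: what stability to expect

A few compounds are considered here, and "the series" means these few. Any claim that something is new, unique, unknown or untested is made for them only; others in the source may bear on it.

Compound 1 `O=C(OC1CCC(CN2CCN(c3cc(=O)c4cc(C(F)(F)F)cc([N+](=O)[O-])c4s3)CC2)CC1)c1ccccc1` gives 68.1%
Compound 2 `O=c1cc(N2CCN(CC3CCC(NS(=O)(=O)c4ccccc4)CC3)CC2)sc2c([N+](=O)[O-])cc(C(F)(F)F)cc12` gives 95.3%
Compound 3 `O=c1cc(N2CCN(CC3CCCCC3)CC2)sc2c(NO)cc(C(F)(F)F)cc12` gives 47.8%

These numbers come from an ADME assay on cells (Hepatocyte, Mus musculus) for metabolic stability, with a stated time of 30 min; a higher number here means that more of the compound is left, a lower number that less of the compound is left. Compound 2 stands highest of the three at 95.3%, and both other compounds lie beyond the scatter from it. Compound 4 `Cc1ccc(C(=O)OC2CCC(CN3CCN(c4cc(=O)c5cc(C(F)(F)F)cc([N+](=O)[O-])c5s4)CC3)CC2)cc1` has not yet been measured.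

The change from compound 2 to compound 4 places ((4-methylphenyl)carbonyl)oxy in place of (phenylsulfonyl)amino on a saturated ring carbon. Among the compounds with values here, one measured step bears on this exchange at the same place, and it went the other way: a number 27.2 percentage points higher from compound 1 to compound 2 (beyond the scatter). That step was modest but beyond the scatter, with (phenylsulfonyl)amino replacing benzoyloxy. The group entering compound 4 is close to the benzoyloxy of compound 1, apart from its 4-methyl. Within the data shown here, compound 3 differs from the others in more than one place and offers no comparable step. Among the measured compounds shown here, no measured compound shows what the 4-methyl adds, and this widens the range.

A fall of similar size is therefore expected, and the estimated step is a number 31.3 percentage points lower from compound 2 to compound 4 (beyond the scatter). Compound 4 is expected to give 64%, with an estimated range of 46% to 80%.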

Compound 4, percent of the compound remaining: 18%
Beside the measured number, compound 4's estimate is 46 percentage points above it; the measured number lies below the stated range.
By their numbers in this assay, from the lowest: compound 4; then compound 3; then compound 1; then compound 2.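

In this assay, within the data shown here, the exchange on the saturated ring carbon turns out far larger than the one earlier step at this place suggested: a number 77.3 percentage points lower from compound 2 to compound 4 (beyond the scatter), against a number 27.2 percentage points higher from compound 1 to compound 2 (beyond the scatter) in the opposite direction. The new pair that differs only by methyl in place of hydrogen on an aromatic carbon shows that the outcome at this position is highly sensitive to a very small edit, with a number 50.1 percentage points lower from compound 1 to compound 4 (beyond the scatter), a step larger than the one separating the benzoyloxy and (phenylsulfonyl)amino groups themselves. No measurement here accounts for why one added methyl moves the read-out so far.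

The compounds shown leave open whether the same methyl on the aromatic ring of the (phenylsulfonyl)amino group would bring a comparable fall, or whether the large step belongs to the ester-linked series alone. They also leave open how a chlorine or a methoxy group in place of that methyl would behave, and whether an amide link in place of the ester oxygen would keep ((4-methylphenyl)carbonyl) closer to the number of compound 2.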